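A few compounds are considered here, and "the series" means these few. Any claim that something is new, unique, unknown or untested is made for them only; others in the source may bear on it.

Measured so far in a functional assay on RAW264.7 cells (Mus musculus) for inhibition, read by immunoassay, with a stated time of 12 h, tested at 30 uM; on this read-out lower numbers stand for less inhibition and higher numbers for more inhibition at the one concentration tested (going by the name of the read-out):
compound 1, `CC(C)c1ccc(COc2ccccc2C2CC(=O)c3ccccc3O2)cc1`, gives 91.5%
compound 2, `C=CCOc1ccccc1C1CC(=O)c2ccccc2O1`, gives 49.3%
compound 3, `CC(C)=CCOc1ccccc1C1CC(=O)c2ccccc2O1`, gives 41.8%

Compound 2 stands second highest of these three numbers. Its nearest neighbour is compound 3, with a step of a number 7.5 percentage points lower from compound 2 to compound 3 (within the scatter); its furthest is compound 1, with a step of a number 42.2 percentage points lower from compound 1 to compound 2 (beyond the scatter).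

Compound 4, `COCOc1ccccc1C1CC(=O)c2ccccc2O1`, differs from compound 2 by methoxy in place of vinyl on a saturated chain carbon bound to an oxygen on an aromatic ring. Among the measured compounds shown here, the only step that changes the same place without the large aryl group is a number 7.5 percentage points lower from compound 2 to compound 3 (within the scatter), and it lay within the scatter. For the measured compounds named here, no measured step swaps vinyl for methoxy, so little beyond the scatter is expected in this assay, perhaps a mild lowering. Compound 4 is therefore estimated at 42%, between 22% and 62%, a step of a number 7.3 percentage points lower from compound 2 to compound 4 (within the scatter).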

Compound 4, a percentage reported as inhibition, at one concentration (the size of the read-out at that concentration, not a potency): 35.2%
The estimate for compound 4 lay 6.8 percentage points above the measured number; low and high end bracket the measured number.
By their numbers in this assay, from the lowest: compounds 4, 3 and 2 (each within the scatter of the next, the first and the last beyond it); then compound 1.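

In this assay, methoxy in place of vinyl gives a number 14.1 percentage points lower from compound 2 to compound 4 (beyond the scatter) and so shows that a small group at this place can shift the number, even with the large aryl group absent. Methoxy in place of 2-methylprop-1-en-1-yl gives only a number 6.6 percentage points lower from compound 3 to compound 4 (within the scatter) here, while methoxy in place of 4-isopropylphenyl gives a number 56.3 percentage points lower from compound 1 to compound 4 (beyond the scatter) and leaves the aryl change by far the largest. Nothing available explains these differences.

On these data alone, whether plain phenyl in place of 4-isopropylphenyl would keep the high number stays open, as does the effect of an amine or a carboxylic acid on the chain at this place.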